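From a Z to an E Double Bond in Compound 3

A few compounds are considered here, and "the series" means these few. Any claim that something is new, unique, unknown or untested is made for them only; others in the source may bear on it.

The measured compounds:
compound 1, `C=CCCCCCCCCCOC[C@@H]1C[C@@H](O)CN1C(=O)OC(C)(C)C`, gives 39000 nM
compound 2, `CCCCCCCC/C=C\CCCCCCCCOC[C@@H]1C[C@@H](O)CN1C(=O)OC(C)(C)C`, gives 40000 nM

Both numbers come from a functional assay on HeLa cells (Homo sapiens) for inhibition, with a stated time of 72 h; a lower number here means a stronger inhibitor, a higher number a weaker inhibitor. Going by the values given here, compound 2 has the higher of the two numbers, but its only neighbour is compound 1, and the step of a 1.0-fold higher number from compound 1 to compound 2 (0.01 log units; within the scatter) is within the scatter, so the two compounds cannot be told apart on these data.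

Compound 3, `CCCCCCCC/C=C/CCCCCCCCOC[C@@H]1C[C@@H](O)CN1C(=O)OC(C)(C)C`, differs from compound 2 as follows: the two compounds have the same atoms and bonds and differ only in configuration as drawn: 1 of 3 stereo elements differ; a double bond is drawn Z in compound 2 and E in compound 3. Among the compounds with values here, only one measured step exists for comparison, the one from compound 1 to compound 2, and it concerned a different change at the end of the chain and stayed within the scatter. Within the data shown here, no measured step speaks to a change of double-bond geometry alone. The step of no change at the digits printed from compound 2 to compound 3 (within the scatter) is therefore expected to stay within the scatter, in no particular direction.

For compound 3 the estimate in this assay is 40000 nM, with a range from 20000 nM to 80000 nM.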

Compound 3, half-maximal inhibitory concentration: 29500 nM
Compound 3: the middle estimate sits 1.4-fold (0.13 log units) above what was measured, and the stated range covers the measured number.
By their numbers in this assay, from the lowest: compounds 3, 1 and 2 (each within the scatter of the next).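

In this assay, a change of double-bond geometry alone gives a 1.4-fold lower number from compound 2 to compound 3 (0.13 log units; within the scatter), so the Z and E forms of this chain cannot be told apart on these data. This step isolates the geometry of the double bond, with nothing else in the structure altered: the fact that compounds 2 and 3 differ only in the configuration as drawn Set against the chain with the terminal alkene, the E chain gives a 1.3-fold lower number from compound 1 to compound 3 (0.12 log units; within the scatter), so among these compounds neither the longer chain nor the double-bond geometry moves the number beyond the scatter.

The compounds shown leave open whether a different kind of group at the end of the chain, such as an amine or a carboxylic acid, would move the number beyond the scatter. They also leave open whether a fully saturated chain of the same length would stay within the scatter of these compounds.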